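Trading a hydroxyphenyl for a methyl on the shared core

The source may hold more compounds than are shown below. What is called first, only, known or untested is meant among the compounds shown, and "the series" means these compounds.

Of the compounds shown here, three built on one shared core have been tested in a functional assay on AGS cells (Homo sapiens) for cytotoxicity, read by MTT assay, with a stated time of 48 h; a higher number here means a weaker inhibitor, a lower number a stronger inhibitor. Compound 1 `Cc1nc2c3ccccc3ccc2c2nc3c(ccc4ccccc43)c(-c3ccccc3N)c12` gives 12100 nM. Compound 2 `Cc1nc2c3ccccc3ccc2c2nc3c(ccc4ccccc43)c(-c3ccccc3Cl)c12` gives 52500 nM, and compound 3 `Cc1nc2c3ccccc3ccc2c2nc3c(ccc4ccccc43)c(-c3ccc(O)cc3)c12` gives 14200 nM. Of these three numbers, compound 3 stands second highest; it lies within the scatter of compound 1, while the gap to compound 2 is larger, shown by a 3.7-fold lower number from compound 2 to compound 3 (0.57 log units; beyond the scatter). The remaining steps are a 1.2-fold higher number from compound 1 to compound 3 (0.07 log units; within the scatter) and a 4.3-fold higher number from compound 1 to compound 2 (0.64 log units; beyond the scatter).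

Compound 4 `Cc1nc2c3ccccc3ccc2c2nc3c(ccc4ccccc43)c(C)c12` differs from compound 3 in one place: methyl in place of 4-hydroxyphenyl on an aromatic carbon. Within the data shown here, no measured step matches this change. The two steps that bear on it, a 1.2-fold higher number from compound 1 to compound 3 (0.07 log units; within the scatter) and a 3.7-fold lower number from compound 2 to compound 3 (0.57 log units; beyond the scatter), each swapped one six-membered aromatic ring for another and were at most modest. Dropping the ring entirely goes further than either, so a larger step with an uncertain direction seems plausible; a weaker result is taken as somewhat more likely. The estimate for compound 4 in this assay is 30000 nM, expected to fall between 8000 nM and 120000 nM, which corresponds to an expected step of a 2.1-fold higher number from compound 3 to compound 4 (0.32 log units; beyond the scatter).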

Compound 4, half-maximal inhibitory concentration: > 80000 nM
Compound 4 ended at the assay's limit (the forecaster's own chance of this, stated with the estimate: 15%); middle value at least 2.6-fold (0.42 log units) from the limit.
By their numbers in this assay, from the lowest: compounds 1 and 3 (each within the scatter of the next); then compound 2. At a limit, above all of these: compound 4.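

Compound 4 stands at a limit of this assay, so it has no exact number: the limit of > 80000 nM in this assay, at which 1 of the 4 values shown sits. The earlier compounds shown here only exchanged one substituted aromatic ring for another at this position, whereas replacing the ring with methyl reaches further, giving an at least 5.6-fold higher number from compound 3 to compound 4 (0.75 log units; beyond the scatter) and an at least 6.6-fold higher number from compound 1 to compound 4 (0.82 log units; beyond the scatter). The comparison with compound 2 is less firm, since an at least 1.5-fold higher number from compound 2 to compound 4 (0.18 log units; that floor lies within the scatter) shows that this gap may be small, so having a ring here does not by itself keep the number low, as the 2-chlorophenyl of compound 2 shows.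

An unsubstituted phenyl at this position would help separate the contribution of the ring from that of its hydroxyl or amino group. As far as these compounds go, it also remains open whether an amine or a carboxylic acid placed directly on this carbon would give numbers nearer those of compound 1 and compound 3.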